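Swapping Trifluoromethyl for Isopropyl on a Shared Core

The source may report more compounds than this note shows. Statements on the series, on what has been measured and on what is new or still open speak of the compounds shown alone.

Of the compounds shown here, three built on one shared core have been tested in a functional assay on MCF7 cells (Homo sapiens) for cytotoxicity, read by CellTiter-Glo, with a stated time of 5 days; a lower number here means a stronger inhibitor, a higher number a weaker inhibitor. Compound 1 `CCC/C(=C(/c1ccc(/C=C/C(=O)O)cc1)c1ccc2[nH]ncc2c1)c1ccccc1` carries a propyl group on a double-bonded chain carbon bound to an aromatic carbon and a double-bonded chain carbon, and in this assay compound 1 gives 11 nM. Compound 2 `CCCC/C(=C(/c1ccc(/C=C/C(=O)O)cc1)c1ccc2[nH]ncc2c1)c1ccccc1` carries a butyl group at that place, and compound 2 gives 10 nM. Compound 3 `O=C(O)/C=C/c1ccc(/C(=C(\c2ccccc2)C(F)(F)F)c2ccc3[nH]ncc3c2)cc1` carries a trifluoromethyl there, and compound 3 gives 5.5 nM. Among the three, compound 3 gives the lowest number, yet the gaps are small: a 2.0-fold lower number from compound 1 to compound 3 (0.30 log units; within the scatter) and a 1.8-fold lower number from compound 2 to compound 3 (0.26 log units; within the scatter), so the three cannot be told apart with confidence.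

Compound 4 `CC(C)/C(=C(/c1ccc(/C=C/C(=O)O)cc1)c1ccc2[nH]ncc2c1)c1ccccc1` has not yet been measured. It differs from compound 3 in one place: isopropyl in place of trifluoromethyl on a double-bonded chain carbon bound to an aromatic carbon and a double-bonded chain carbon. Among the measured compounds shown here, the steps that bear on this change are a 2.0-fold lower number from compound 1 to compound 3 (0.30 log units; within the scatter) and a 1.8-fold lower number from compound 2 to compound 3 (0.26 log units; within the scatter), both of which replaced an alkyl group with a trifluoromethyl, while a 1.1-fold lower number from compound 1 to compound 2 (0.04 log units; within the scatter) shows that exchanging one alkyl group for a longer one changed little. Putting an alkyl group back in place of the trifluoromethyl is therefore expected to give no step beyond the scatter, with the number drifting, if at all, back toward those of compound 1 and compound 2. For compound 4 the expected step is a 1.6-fold higher number from compound 3 to compound 4 (0.21 log units; within the scatter). The estimate for compound 4 in this assay is 9 nM, with a range from 4 nM to 20 nM.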

Compound 4, half-maximal inhibitory concentration: 4 nM
Beside the measured number, compound 4's estimate is 2.3-fold (0.35 log units) above it; measured number inside the range.
By their numbers in this assay, from the lowest: compounds 4, 3, 2 and 1 (each within the scatter of the next, the first and the last beyond it).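

In this assay, the place on a double-bonded chain carbon bound to an aromatic carbon and a double-bonded chain carbon now gives its first steps beyond the scatter: a 2.8-fold lower number from compound 1 to compound 4 (0.44 log units; beyond the scatter) and a 2.5-fold lower number from compound 2 to compound 4 (0.40 log units; beyond the scatter), both modest, so exchanging one alkyl group for another here can matter, whereas propyl and butyl could not be told apart. Meanwhile, a 1.4-fold lower number from compound 3 to compound 4 (0.14 log units; within the scatter) stays within the scatter, so isopropyl, which has no fluorine, cannot be told apart from trifluoromethyl, and fluorine is not required for a number in this range among the compounds shown. No measurement is available to explain why isopropyl differs from the straight alkyl chains in this cell assay.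

The compounds shown leave open whether the difference follows branching of the alkyl group, which a tert-butyl or cyclopropyl group at this place could test alongside a shorter chain such as ethyl. They also leave open how this place responds to a group that brings in nitrogen or oxygen, such as an amine or a carboxylic acid.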